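From Compound 2 to Compound 4: An Untested Exchange

The source may report more compounds than this note shows. Statements on the series, on what has been measured and on what is new or still open speak of the compounds shown alone.

Three compounds carrying the (1,3-benzoxazol-2-yl)sulfanyl group have been measured in a functional assay on MCF7 cells (Homo sapiens) for cytotoxicity, read by MTT assay, with a stated time of 24 h; a higher number here means a weaker inhibitor, a lower number a stronger inhibitor. Compound 1 (`COc1cc2ncnc(Nc3cccc(C(F)(F)F)c3)c2cc1OCCCSc1nc2ccccc2o1`) gives 4030 nM, compound 2 (`CCc1cc(Br)ccc1Nc1ncnc2cc(OC)c(OCCCSc3nc4ccccc4o3)cc12`) gives 17300 nM, and compound 3 (`COc1cc2ncnc(Nc3ccc(C)cc3)c2cc1OCCCSc1nc2ccccc2o1`) gives 12100 nM. Compound 2 stands at the high end of these numbers, but it does not stand there alone. The measured steps that reach it are a 1.4-fold lower number from compound 2 to compound 3 (0.16 log units; within the scatter) and a 4.3-fold higher number from compound 1 to compound 2 (0.63 log units; beyond the scatter). The remaining step is a 3.0-fold higher number from compound 1 to compound 3 (0.48 log units; beyond the scatter).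

Compound 4 (`CCCCc1nc(Cl)c(CO)n1CCCOc1cc2c(Nc3ccc(Br)cc3CC)ncnc2cc1OC`) has not yet been measured. It keeps the 4-bromo-2-ethylphenyl group of compound 2, and the change lies elsewhere: 2-butyl-4-chloro-5-(hydroxymethyl)-1H-imidazol-1-yl in place of (1,3-benzoxazol-2-yl)sulfanyl on a saturated chain carbon, three bonds along the chain from an oxygen on an aromatic ring.

All three measured steps exchange only the group on a nitrogen on an aromatic ring. None of them touches the group that leaves here, and the data offer no direct reading of this exchange. For the measured compounds named here, they show only that the changes made so far have been modest or within the scatter. No direction can be argued from them, and the central expectation in this assay is no step beyond the scatter, with real uncertainty on both sides. For compound 4 the estimated value is 14000 nM, with an expected range from 4000 nM to 45000 nM. This expectation amounts to a 1.2-fold lower number from compound 2 to compound 4 (0.09 log units; within the scatter).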

Compound 4, half-maximal inhibitory concentration: 10600 nM
Compound 4: middle estimate off by 1.3-fold (0.12 log units), on the high side, within the range that was stated.
By their numbers in this assay, from the lowest: compound 1; then compounds 4, 3 and 2 (each within the scatter of the next).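

For the compounds shown here, the step of a 1.6-fold lower number from compound 2 to compound 4 (0.21 log units; within the scatter) is the only reading in this assay of the place on a saturated chain carbon, three bonds along the chain from an oxygen on an aromatic ring; all the earlier steps exchanged the group on a nitrogen on an aromatic ring. With the 4-bromo-2-ethylphenyl group held fixed, a group with two rings and no hydrogen-bond donor gave way to one with a single ring and a hydrogen-bond donor, and the two numbers still lie within the scatter of each other. No measured information bears on this outcome.

As far as these compounds go, it remains open whether 2-butyl-4-chloro-5-(hydroxymethyl)-1H-imidazol-1-yl would read the same way alongside the 3-(trifluoromethyl)phenyl group of compound 1 or the 4-methylphenyl group of compound 3. From the compounds shown here alone, it is equally open whether a morpholine, a carboxylic acid or a simple amine in this place, or a longer chain leading to it, would also stay within the scatter of compound 2.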